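A few compounds are considered here, and "the series" means these few. Any claim that something is new, unique, unknown or untested is made for them only; others in the source may bear on it.

Compounds measured so far:
Compound 1 `COc1ccc(-c2cc(=O)c3c(OC)cc(OC)cc3[nH]2)cc1`: in a functional assay on KOPN-8 cells (Homo sapiens) for antiproliferative activity, with a stated time of 72 h (a lower number here means that less compound is needed, a higher number that more compound is needed for the effect), compound 1 gives > 31100 nM, a limit of the assay rather than a number.
Compound 2 `COc1ccc(-c2c(Br)c(=O)c3c(OC)cc(OC)cc3n2S(=O)(=O)c2ccc(OC)cc2)cc1`: compound 2 gives 2580 nM in this assay.
Compound 3 `COc1ccc(-c2c(I)c(=O)c3c(OC)cc(OC)cc3n2S(=O)(=O)c2ccc(OC)cc2)cc1`: compound 3 gives 8580 nM in this assay.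

Compound 1 thus stands at the limit (the limit of > 31100 nM in this assay, at which 1 of the 3 values shown sits). Compound 4 `COc1ccc(-c2cc(=O)c3c(OC)cc(OC)cc3n2S(=O)(=O)c2ccc(C#N)cc2)cc1` differs from compound 1 by (4-cyanophenyl)sulfonyl in place of hydrogen on an aromatic nitrogen. Within the data shown here, no measured pair differs by this change alone; the one measured step, a 3.3-fold higher number from compound 2 to compound 3 (0.52 log units; beyond the scatter), is a halogen swap between two compounds that both carry a (4-methoxyphenyl)sulfonyl group and both give numbers rather than a limit. Compound 4 carries a sulfonyl group too, without a halogen and with a nitrile in place of the methoxy, so in this assay compound 4 is expected to show an at least 3.8-fold lower number from compound 1 to compound 4 (0.58 log units; beyond the scatter). For compound 4 the estimate is 8000 nM, range 2000 nM to 40000 nM, with wide uncertainty.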

Compound 4, half-maximal effective concentration: > 17200 nM
Compound 4 ended at the assay's limit (the forecaster's own chance of this, stated with the estimate: 30%); middle value at least 2.1-fold (0.33 log units) from the limit.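

Among these compounds, compound 1 and compound 4 both end at limits of the assay in this assay, so no step between them can be read. As far as these compounds go, whether (4-cyanophenyl)sulfonyl in place of hydrogen on the aromatic nitrogen changes the number at all stays open.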